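Replacing Cyano by Chloro Where Every Value Is a Limit

A few compounds are considered here, and "the series" means these few. Any claim that something is new, unique, unknown or untested is made for them only; others in the source may bear on it.

Compound 1, `CSCC[C@H](NC(=O)c1ccc(NCc2cncn2Cc2ccc(Cl)cc2)cc1-c1ccccc1)C(=O)O`, in a functional assay on NIH3T3 cells (Mus musculus) (on this read-out higher numbers stand for an effect only at larger amounts of compound and lower numbers for an effect already at smaller amounts), gives > 10 uM, which is a limit of the assay and not a number.
Compound 2, `CSCC[C@H](NC(=O)c1ccc(NCc2cncn2Cc2ccc([N+](=O)[O-])cc2)cc1-c1ccccc1)C(=O)O`, in this assay gives > 10 uM, again a limit.
Compound 3, `CSCC[C@H](NC(=O)c1ccc(NCc2cncn2Cc2ccccc2C#N)cc1-c1ccccc1)C(=O)O`, in this assay gives > 10 uM, again a limit.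

Compound 3 thus stands where every measured compound of this set stands: at the limit of > 10 uM in this assay, at which 3 of the 3 values shown sit. Compound 4, `CSCC[C@H](NC(=O)c1ccc(NCc2cncn2Cc2ccccc2Cl)cc1-c1ccccc1)C(=O)O`, differs from compound 3 by chloro in place of cyano on an aromatic carbon. The measured steps, a step that the two limits leave unreadable from compound 1 to compound 2, a step that the two limits leave unreadable from compound 1 to compound 3 and a step that the two limits leave unreadable from compound 2 to compound 3, all run from one limit to another, so none of them has a readable size, and none of them involves a change of this kind. There is therefore no measured basis for expecting a gain or a loss beyond the scatter in this assay. Compound 4 is expected, by the step that the limit leaves unreadable from compound 3 to compound 4, to remain at the limit like compound 3. Compound 4 is estimated at 15 uM, with a range from 5 uM to 50 uM.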

Compound 4, concentration for half-maximal effect: > 10 uM
Compound 4 was reported as a limit (the forecaster's own chance of this, stated with the estimate: 80%); the middle value is on the limit's open side.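

The steps from compound 1, compound 2 and compound 3 to compound 4 cannot be read, as all four compounds sit at the same limit: the limit of > 10 uM in this assay, at which 4 of the 4 values shown sit.

The compounds shown leave open what concentration any of them would need in this assay, and whether exchanging chloro, cyano and nitro changes that concentration at all.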